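The source may hold more compounds than are shown below. What is called first, only, known or untested is meant among the compounds shown, and "the series" means these compounds.

Compound 1 `C/C(=C\c1cc(-c2cccnc2)co1)C(N)=O` gives 6620 nM in a functional assay on A549 cells (Homo sapiens) for cytotoxicity, read by CCK-8 assay, with a stated time of 24 h; a higher number here means a weaker inhibitor, a lower number a stronger inhibitor.
Compound 2 `C/C(=C\c1cc(-c2ccc(C)nc2)co1)C(N)=O` gives > 50000 nM in this assay, a limit of the assay rather than a number.
Compound 3 `C/C(=C\c1cccc(-c2ccccc2)c1)C(N)=O` gives > 50000 nM in this assay, again a limit of the assay.

Across the pair that is fully comparable, methyl in place of hydrogen on an aromatic carbon produced an at least 7.5-fold higher number from compound 1 to compound 2 (0.87 log units; beyond the scatter). The size of that step is bounded only from below, since the limit of > 50000 nM in this assay, at which 2 of the 3 values shown sit, marks where the reading for compound 2 ends. Compound 3 carries a different core from compound 1, and the difference between the two cores is not broken down here.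

Compound 4 `C/C(=C\c1cccc(-c2ccc(C)cc2)c1)C(N)=O` is yet to be measured in this assay. It arises from compound 3 by methyl in place of hydrogen on an aromatic carbon. This is the same kind of change as that from compound 1 to compound 2, though not the same: there the methyl entered a six-membered aromatic ring with 1 nitrogen, next to the ring nitrogen, whereas here it enters a six-membered aromatic ring of carbon only. Compound 3 already sits at the limit, and the earlier methyl step raised the number, so compound 4 is expected to give 80000 nM, with a step that the limit leaves unreadable from compound 3 to compound 4 expected as the step. That estimate rests on compound 3 giving > 50000 nM and on an at least 7.5-fold higher number from compound 1 to compound 2 (0.87 log units; beyond the scatter).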

Compound 4, half-maximal inhibitory concentration: 5100 nM
Compound 4: the middle estimate sits 16-fold (1.20 log units) above what was measured; measured number outside the range, below it.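

Methyl in place of hydrogen on an aromatic carbon, here para to a large group on a six-membered aromatic ring of carbon only, gave an at least 9.8-fold lower number from compound 3 to compound 4 (0.99 log units; beyond the scatter) in this assay. The change therefore did not carry over between these two cores, and its direction reversed: the same change on two cores in this assay, an at least 7.5-fold higher number (0.87 log units; beyond the scatter) from compound 1 to compound 2 and an at least 9.8-fold lower number (0.99 log units; beyond the scatter) from compound 3 to compound 4, at least 74-fold (1.86 log units) apart, beyond the scatter of two such steps

This shows that, within these two pairs, the methyl step on the core of compound 1 did not predict the step on the core of compound 3, but it rests on one pair per core, with the methyl entering a different ring in each, and it gives neither a reason for the reversal nor the full size of either step, since one end of each is a limit of the assay: the limit of > 50000 nM in this assay, at which 2 of the 4 values shown sit.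

The compounds shown leave open whether an ethyl, a methoxy or an amine on the same carbon of compound 3 would follow the methyl of compound 4. They also leave open how a carboxylic acid in place of the primary amide would read on either core.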